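Aryl-to-hexyl exchange on the ether chain of compound 1

This account rests on a few compounds, and the source may have more. Where it says the series, first, only, none or still open, it means among the compounds named here.

Compound 1 `[O-][n+]1nc(NCOCc2ccc(Cl)cc2)[n+]([O-])c2ccccc21` gives 1470 nM in a functional assay on A549 cells (Homo sapiens) for cytotoxicity, read by MTT assay, with a stated time of 72 h (on this read-out higher numbers stand for weaker inhibition and lower numbers for stronger inhibition), the lowest of the three numbers in the set. Compound 3 `CC(OCNc1n[n+]([O-])c2ccccc2[n+]1[O-])c1ccccc1` gives 2710 nM, a gap to compound 1 that lies within the scatter. Among the measured compounds shown here, compound 2 `[O-][n+]1nc(NCOCc2ccc(C(F)(F)F)cc2)[n+]([O-])c2ccccc21` gives 8420 nM; the one change with a measured step is a 5.7-fold higher number from compound 1 to compound 2 (0.76 log units; beyond the scatter).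

Compound 4 `CCCCCCCOCNc1n[n+]([O-])c2ccccc2[n+]1[O-]` differs from compound 1 as follows: hexyl in place of 4-chlorophenyl on a saturated chain carbon bound to an oxygen on a saturated carbon. For the measured compounds named here, no measured step covers the loss of the aromatic ring itself; the only step in hand, from compound 1 to compound 2, shows that altering the substituent on that ring already moves the number beyond the scatter, while the comparison of compound 1 with compound 3 shows that a change on the chain carbon does not. Replacing the ring entirely is a larger change than either, so a step toward a higher number in this assay is expected, though its size is uncertain.

The step expected from compound 1 to compound 4 is a 2.0-fold higher number from compound 1 to compound 4 (0.31 log units; beyond the scatter). Compound 4 is therefore estimated at 3000 nM, with a range from 1000 nM to 9000 nM.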

Compound 4, half-maximal inhibitory concentration: 2610 nM
For compound 4 the middle estimate is 1.1-fold (0.06 log units) above the measured one; the measured number falls inside the stated range.
By their numbers in this assay, from the lowest: compounds 1, 4 and 3 (each within the scatter of the next); then compound 2.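

In this assay, hexyl in place of 4-chlorophenyl on a saturated chain carbon bound to an oxygen on a saturated carbon gives a 1.8-fold higher number from compound 1 to compound 4 (0.25 log units; within the scatter) and so the aromatic ring is not needed at this position for a number in this range. The exchange on the ring itself, a 5.7-fold higher number from compound 1 to compound 2 (0.76 log units; beyond the scatter), lies beyond the scatter, whereas the exchange of the whole ring for hexyl lies within it, so among these compounds trifluoromethyl in place of chloro is the only listed change to move the number beyond the scatter. Nothing available accounts for this result.

As far as these compounds go, whether a longer chain, or an amine or a carboxylic acid in place of hexyl on the same carbon, would keep the number in this range remains open. Also open, from the compounds shown here alone, is whether a shorter chain would do the same.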